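This account rests on a few compounds, and the source may have more. Where it says the series, first, only, none or still open, it means among the compounds named here.

Working notes on the series. Compound 1 `COc1cc(C)cc(-c2c(-c3ccnc(-c4ccc(N(C)C)cc4)c3)cnn2CC#N)c1` and compound 2 `COc1cc(C)cc(-c2nn(CC#N)cc2-c2ccnc(-c3ccc(N(C)C)cc3)c2)c1` are close relatives; compound 3 `COc1cc(C)cc(-c2nn(CC#N)cc2-c2ccc(-c3cccc(C(C)=O)c3)nc2)c1` is the third member measured. In a functional assay on MOLT-4 cells (Homo sapiens) for cytotoxicity, read by sulforhodamine B assay, with a stated time of 48 h, tested at 10 uM (a lower number here means a stronger effect, a higher number a weaker effect of the compound at the concentration tested), compound 1 gives 1%. Compound 2 gives 1% in this assay, level with compound 1 at the digits shown and within the scatter of it; the two together are the lowest numbers of the three. Compound 3 gives 14% in this assay, a number higher than that of compound 2 by more than the scatter.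

Compound 4 `Cc1cc(O)cc(-c2nn(CC#N)cc2-c2ccnc(-c3ccc(N(C)C)cc3)c2)c1` has not yet been measured. It differs from compound 2 by one change: hydrogen in place of methyl on an oxygen on an aromatic ring. For the measured compounds named here, no pair of measured compounds isolates this change, so the size of the step can only be guessed. A small step is expected, if any, in the direction of a higher number, because compound 2 gives 1% in this assay, a number that together with that of compound 1 is the lowest of the three measured. The step of a number 5 percentage points higher from compound 2 to compound 4 (within the scatter) is the expectation written into the estimate. Compound 4 is therefore expected to give about 6% in this assay, with a range from 0% to 28%.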

Compound 4, a percentage reported as activity, at one concentration (the size of the read-out at that concentration, not a potency): -6%
Compound 4: the middle estimate sits 12 percentage points above what was measured, and the stated range ends above it.
By their numbers in this assay, from the lowest: compounds 4, 1 and 2 (each within the scatter of the next); then compound 3.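

In this assay, for the compounds shown here, the change from methoxy to hydroxy on the 3-methoxy-5-methylphenyl group gives a number 7 percentage points lower from compound 2 to compound 4 (within the scatter) and is the first change isolated in one place. Compound 4 gives -6% at the single concentration tested, so the methyl on this oxygen is not needed to keep the number level with that of compound 2. No supporting measurement bears on why this change is tolerated.

Still open, as far as these compounds go, is whether a larger group on this oxygen, such as ethoxy or benzyloxy, or an amine in its place, would stay within the scatter of compound 2. Also open, from the compounds shown here alone, is whether the same change would give a similar step on compound 1 or compound 3, and whether compound 2 and compound 4 differ at lower concentrations.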